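Chloro on a phenyl of compound 1

The source may report more compounds than this note shows. Statements on the series, on what has been measured and on what is new or still open speak of the compounds shown alone.

Measured in an ADME assay on HaCaT cells (Homo sapiens) for cytotoxicity, read by MTT assay, with a stated time of 48 h (a lower number here means a stronger inhibitor, a higher number a weaker inhibitor), all three values being limits:
Compound 1 `Fc1ccc2[nH]c(-c3cn(-c4ccccc4)nc3-c3ccccc3)nc2c1`: > 50000 nM
Compound 2 `Cc1ccc2[nH]c(-c3cn(-c4ccccc4)nc3-c3ccccc3)nc2c1`: > 50000 nM
Compound 3 `O=C(OCc1ccccc1)c1ccc2[nH]c(-c3cn(-c4ccccc4)nc3-c3ccccc3)nc2c1`: > 50000 nM

Compound 1 stands at a limit, not at a number, and so does the rest of the series: the limit of > 50000 nM in this assay, at which 3 of the 3 values shown sit. Compound 4 `Fc1ccc2[nH]c(-c3cn(-c4ccccc4)nc3-c3ccc(Cl)cc3)nc2c1` differs from it in one place: chloro in place of hydrogen on an aromatic carbon. In words, phenyl becomes 4-chlorophenyl.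

The measured steps give no size: a step that the two limits leave unreadable from compound 1 to compound 2, a step that the two limits leave unreadable from compound 1 to compound 3 and a step that the two limits leave unreadable from compound 2 to compound 3. All three also change a different place from this phenyl.

Resting on compound 1 at > 50000 nM, a limit, no step beyond the scatter is expected in this assay, in either direction. The expected change is a number no higher from compound 1 to compound 4 (the limit leaves the size open). For compound 4 the estimate is 50000 nM, with an expected range of 20000 nM to 100000 nM.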

Compound 4, half-maximal inhibitory concentration: > 50000 nM
Compound 4 ended at the assay's limit; the forecaster's own chance of this, stated with the estimate: 70%; the middle value sits exactly at the limit.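

For the compounds shown here, compound 4 gives > 50000 nM, a limit, as compound 1 does, so no step between compound 1 and compound 4 can be read. The compounds shown leave open whether any of these groups shifts the half-maximal inhibitory concentration in this assay, because the whole series sits at one value: the limit of > 50000 nM in this assay, at which 4 of the 4 values shown sit.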